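A few compounds are considered here, and "the series" means these few. Any claim that something is new, unique, unknown or untested is made for them only; others in the source may bear on it.

Measured so far, in an ADME assay on MT4 cells (Homo sapiens) for cytotoxicity, read by MTT assay; on this read-out higher numbers stand for lower toxicity in this test and lower numbers for higher toxicity in this test:
compound 1 `Cc1ccc(NC(=O)CSc2nncnc2-c2cccc3ccccc23)c(Br)c1` gives 166000 nM
compound 2 `O=C(CSc1nncnc1-c1ccccc1Cl)Nc1ccccc1` gives 127000 nM
compound 3 `CCOC(=O)c1ccc(NC(=O)CSc2nncnc2-c2ccccc2Cl)c(Br)c1` gives 69000 nM

Compound 1 has the highest of the three numbers in this assay. Compound 2 sits close to it, within the usual scatter of this assay, so on this read-out the two cannot be told apart. Compound 3 gives a clearly lower number than compound 1, a gap beyond the scatter, so compound 3 is the more toxic of those two in this test.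

Compound 4 `O=C(CSc1nncnc1-c1cccc2ccccc12)Nc1ccccc1` has not yet been measured. It differs from compound 1 in one place: phenyl in place of 2-bromo-4-methylphenyl on an amide-type nitrogen. Within the data shown here, no step between two measured compounds covers this exact change, so the expectation rests on a looser comparison: compound 2 also carries the anilino group and gives a number within the scatter of compound 1, though compound 2 and compound 4 differ elsewhere in the shared core. Exchanging the larger group for the smaller phenyl on the amide-type nitrogen is expected to move the number in this assay only a little, with no direction beyond the scatter. Compound 4 is therefore expected to give about 150000 nM, with a range from 70000 nM to 320000 nM. The step of a 1.1-fold lower number from compound 1 to compound 4 (0.04 log units; within the scatter) that this estimate means is expected to stay within the scatter.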

Compound 4, half-maximal cytotoxic concentration: 154000 nM
Compound 4: middle estimate off by 1.0-fold (0.01 log units), on the low side, within the range that was stated.
By their numbers in this assay, from the lowest: compounds 3, 2, 4 and 1 (each within the scatter of the next, the first and the last beyond it).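

In this assay, among these compounds, compounds 1 and 4 form the first pair that differs in one place, and replacing 2-bromo-4-methylphenyl with phenyl on the amide-type nitrogen gives a 1.1-fold lower number from compound 1 to compound 4 (0.03 log units; within the scatter). The two compounds therefore cannot be told apart on this read-out, even though the group that leaves carries a bromine and a methyl and has 8 heavy atoms against 6 for phenyl. With the core of compound 1 held fixed, this one pair shows that the bromine and the methyl, taken away together, leave no readable mark on the cytotoxicity number. Nothing measured here explains this result.

As far as these compounds go, the bromine and the methyl leave as a pair, so the effect of either one alone stays open, and they could even be offsetting each other. Also open, from the compounds shown here alone, is whether a different kind of group on the amide-type nitrogen, such as a phenyl ring carrying a carboxylic acid or an amine, or a longer chain in place of the ring, would give a number as close to that of compound 1.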